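The compounds below may be only part of what the source reports. "The series", "measured", "known", "first", "only" and "open" are said of these compounds alone.

Measured compounds:
compound 1, `Cc1cc(O)cc(-c2nn(CC#N)cc2-c2ccnc(-c3ccc(Oc4ccccc4)cc3)c2)c1`, -75%
compound 2, `COc1cc(C)cc(-c2nn(CC#N)cc2-c2ccnc(-c3ccc(N(C)C)cc3)c2)c1`, 61%

In a functional assay on Malme-3M cells (Homo sapiens) for cytotoxicity, read by sulforhodamine B assay, with a stated time of 48 h, tested at 1 uM (on this read-out higher numbers stand for a weaker effect at the one concentration tested and lower numbers for a stronger effect), compound 2 gives 61%, the higher of the two numbers; compound 1, which in this assay gives -75%, lies far lower, a gap beyond the scatter. Going by the values given here, compound 1 and compound 2 differ in two places, so no single step connects them; only their two values can be compared.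

Compound 3, `Cc1cc(O)cc(-c2nn(CC#N)cc2-c2ccnc(-c3ccc(N(C)C)cc3)c2)c1`, is the next compound in this series and is still to be measured in this assay. It differs from compound 2 in one place: hydrogen in place of methyl on an oxygen on an aromatic ring, i.e. methoxy to hydroxy on the 3-methoxy-5-methylphenyl, giving 3-hydroxy-5-methylphenyl, while the rest of the structure stays as in compound 2.

Among the compounds with values here, no measured step of this kind exists. Within the data shown here, the only other hydroxy-bearing compound, compound 1, carries a different second aryl group, so its value cannot be assigned to the methoxy-to-hydroxy change alone. A step towards a lower number is expected, a number 36 percentage points lower from compound 2 to compound 3 (beyond the scatter), but of uncertain size. Compound 3 is therefore estimated at 25%, with a range from -50% to 80%.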

Compound 3, a percentage reported as activity, at one concentration (the size of the read-out at that concentration, not a potency): 27%
Beside the measured number, compound 3's estimate is 2 percentage points below it, and the stated range covers the measured number.
By their numbers in this assay, from the lowest: compound 1; then compound 3; then compound 2.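

In this assay, going by these compounds alone, hydrogen in place of methyl on an oxygen on an aromatic ring gives a number 34 percentage points lower from compound 2 to compound 3 (beyond the scatter), the first single-place reading of methoxy to hydroxy, and it moves towards a stronger effect. With the 3-hydroxy-5-methylphenyl held constant, dimethylamino in place of phenoxy on an aromatic carbon gives a number 102 percentage points higher from compound 1 to compound 3 (beyond the scatter), so the phenoxy group goes with the much stronger effect and this is the larger of the two steps. Nothing available explains either step.

From the compounds shown here alone, whether the methoxy-to-hydroxy step keeps its direction and size when phenoxy replaces dimethylamino remains open. Also open, going by these compounds, is what an amine or a carboxylic acid in place of the hydroxy, or ethoxy in place of the methoxy, would do on this ring.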